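Heteroaryl swaps on a shared core: topoisomerase inhibition

A few compounds are considered here, and "the series" means these few. Any claim that something is new, unique, unknown or untested is made for them only; others in the source may bear on it.

Measured so far:
compound 1 `Oc1cccc(-c2cc(-c3ccccc3)cc(-c3cccs3)n2)c1` in an assay on isolated protein for inhibition of DNA topoisomerase 1 (Homo sapiens), with a stated time of 30 min, tested at 20 uM; on this read-out lower numbers stand for a weaker effect and higher numbers for a stronger effect at the one concentration tested: 5.8%
compound 2 `Oc1cccc(-c2cc(-c3ccccc3)cc(-c3ccsc3)n2)c1`: 6.8%
compound 3 `Oc1cccc(-c2cc(-c3ccccc3)cc(-c3ccco3)n2)c1`: 0%

All three numbers are small and sit within the scatter of one another. Compound 3 stands lowest of the three, yet this carries no weight: the step of a number 5.8 percentage points lower from compound 1 to compound 3 (within the scatter) and the step of a number 6.8 percentage points lower from compound 2 to compound 3 (within the scatter) are both within the scatter, as is the step of a number 1 percentage points higher from compound 1 to compound 2 (within the scatter). Exchanging one five-membered heteroaryl for another at this place has therefore produced nothing that can be read as a change.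

Compound 4 `Oc1cccc(-c2cc(-c3ccccc3)cc(-c3ccncc3)n2)c1` is the next case; it differs from compound 3 by pyridin-4-yl in place of furan-2-yl on an aromatic carbon. Among the measured compounds shown here, no measured step exchanges a five-membered ring for a six-membered one, so the only steps that bear on it are the three heteroaryl swaps above, each within the scatter. Compound 4 is expected to show no step beyond the scatter, a number 5 percentage points higher from compound 3 to compound 4 (within the scatter). The estimate for compound 4 is 5%, with a range from 0% to 15%.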

Compound 4, a percentage reported as inhibition, at one concentration (the size of the read-out at that concentration, not a potency): 25.4%
Beside the measured number, compound 4's estimate is 20.4 percentage points below it; the measured number lies above the stated range.
By their numbers in this assay, from the lowest: compounds 3, 1 and 2 (each within the scatter of the next); then compound 4.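

Pyridin-4-yl on this aromatic carbon, next to the ring nitrogen, gives what the five-membered swaps did not: a step in this assay that can be read, in place of furan-2-yl (a number 25.4 percentage points higher from compound 3 to compound 4 (beyond the scatter)), in place of thiophen-3-yl (a number 18.6 percentage points higher from compound 2 to compound 4 (beyond the scatter)) and in place of thiophen-2-yl (a number 19.6 percentage points higher from compound 1 to compound 4 (beyond the scatter)). The position therefore does respond to what it carries, and among these four compounds only compound 4 stands apart from the others. Nothing at hand accounts for this step.

In compound 4 a six-membered ring and a nitrogen at its far point enter together, and the compounds shown do not separate the two. A plain phenyl or a pyridin-3-yl at this place would bear on that question, and an amine on the pyridine ring would test how much further the step can go.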